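A few compounds are considered here, and "the series" means these few. Any claim that something is new, unique, unknown or untested is made for them only; others in the source may bear on it.

Four compounds share one core carrying a seven-membered saturated nitrogen ring and an acid-bearing side chain. Compound 1 is `O=C(O)CC/C=C\CO[C@H]1C(OCc2ccc(-c3ccccc3)cc2)CC[C@@H]1N1CCCCCC1` and compound 2 is `O=C(O)CC/C=C\CO[C@H]1[C@@H](OCc2ccc(-c3ccccc3)cc2)CC[C@@H]1N1CCCCCC1`; they differ only in how one ring carbon is drawn, (the two compounds have the same atoms and bonds; at least one stereo element is drawn with a configuration in one of them and without one in the other: 1 of 4 stereo elements differ; a stereocentre at a saturated ring carbon is drawn without a configuration in compound 1 and S in compound 2). In a functional assay on blood for antagonist activity at thromboxane A2 receptor (Homo sapiens) (a higher number here means weaker binding, a lower number tighter binding), compound 1 gives 12.6 nM, while compound 2 gives 5.01 nM, a 2.5-fold lower number from compound 1 to compound 2 (0.40 log units; beyond the scatter); this step may rest on (the fact that one of compounds 1 and 2 is drawn with a defined configuration and the other without, at the place where they differ), since a single drawn configuration can stand for one member of a pair rather than a mixture.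

Compound 3, `CS(=O)(=O)Nc1cccc(-c2ccc(COC3CC[C@H](N4CCCCCC4)[C@H]3OC/C=C\CCC(=O)O)cc2)c1`, comes from compound 1 by methanesulfonamido in place of hydrogen on an aromatic carbon, a change with the new group meta to a large group. In this assay compound 3 gives 12.6 nM, which is no change at the digits printed from compound 1 to compound 3 (within the scatter).

Compound 4, `CS(=O)(=O)Nc1ccccc1-c1ccc(CO[C@H]2CC[C@H](N3CCCCCC3)[C@H]2OC/C=C\CCC(=O)O)cc1`, is not yet measured. Going by the values given here, it comes from compound 2 by methanesulfonamido in place of hydrogen on an aromatic carbon, a change of the same kind as the one from compound 1 to compound 3, but not the same: here the new group sits ortho to a large group rather than meta. If the step behaves as it did from compound 1 to compound 3, compound 4 is expected to sit close to compound 2, with a step of a 1.1-fold higher number from compound 2 to compound 4 (0.04 log units; within the scatter). The different placement leaves more room for surprise, so the expected range is wide: compound 4 is estimated at 5.5 nM, between 2 nM and 16 nM.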

Compound 4, dissociation constant: 6.31 nM
For compound 4 the middle estimate is 1.1-fold (0.06 log units) below the measured one; low and high end bracket the measured number.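

In this assay, putting methanesulfonamido in place of hydrogen on an aromatic carbon gives a 1.3-fold higher number from compound 2 to compound 4 (0.10 log units; within the scatter), and the same kind of change on the other core gives a matching result: the same change on two cores in this assay, no change at the digits printed (within the scatter) from compound 1 to compound 3 and a 1.3-fold higher number (0.10 log units; within the scatter) from compound 2 to compound 4, 1.3-fold (0.10 log units) apart, within the scatter of two such steps

In these two pairs, then, the change carries from one core to the other with no step beyond the scatter, although the new group sits ortho to a large group in compound 4 and at a different place in compound 3. Going by these compounds alone, this does not show that methanesulfonamido is without effect in general, since it rests on two pairs in a single assay, and each placement appears on only one core, so the influence of the placement cannot be separated from that of the core.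

The compounds shown leave open whether other groups at these places, such as an amine, a carboxylic acid or the longer ethanesulfonamido, would also leave the number within the scatter. They also leave open whether methanesulfonamido would behave the same way if the seven-membered nitrogen ring were replaced by a six-membered one, or if the acid-bearing side chain were shorter or longer.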